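Chloro for Iodo on the Sugar Ring of Compound 1

The source may report more compounds than this note shows. Statements on the series, on what has been measured and on what is new or still open speak of the compounds shown alone.

The study begins with two nucleoside analogues tested in a functional assay on L5178Y cells (Mus musculus) for antiproliferative activity; on this read-out lower numbers stand for stronger inhibition and higher numbers for weaker inhibition. Compound 1, with the structure `Nc1nc(=O)n(C2OC(CO)C(I)C2O)cc1F`, gives 0.08 ug/mL in this assay. Compound 2, with the structure `CS(=O)(=O)O[C@@H]1[C@@H](O)[C@H](n2cc(F)c(N)nc2=O)O[C@@H]1CO`, gives 0.05 ug/mL in this assay. Within the data shown here, with only two compounds measured, compound 1 stands alongside compound 2; the gap between their two numbers lies within the usual scatter of repeated measurements, so neither can be set apart from the other on this evidence.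

The piece now turns to compound 3, with the structure `Nc1nc(=O)n(C2OC(CO)C(Cl)C2O)cc1F`, which has not yet been tested in this assay. Compared with compound 1 it carries the following change: chloro in place of iodo on a saturated ring carbon.

Among the measured compounds shown here, no measured pair in this set shares this kind of change, so there is no step to lean on. The expectation is that the step of no change at the digits printed from compound 1 to compound 3 (within the scatter) will be small, without a clear direction, and not beyond the scatter in this assay. Compound 3 is therefore estimated to give 0.08 ug/mL in this assay, with a range from 0.03 ug/mL to 0.25 ug/mL.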

Compound 3, concentration for 50% inhibition: 1 ug/mL
Compound 3: the middle estimate sits 13-fold (1.10 log units) below what was measured; the whole stated range lies below it.
By their numbers in this assay, from the lowest: compounds 2 and 1 (each within the scatter of the next); then compound 3.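

In this assay, among these compounds, the swap on this saturated ring carbon proves far from silent: chloro in place of iodo gives a 13-fold higher number from compound 1 to compound 3 (1.10 log units; beyond the scatter) and stands as a large step, beyond the scatter, where the earlier compounds offered no step at all. The counts printed for the two groups, in heavy atoms, hydrogen-bond donors and acceptors and net charge, are the same on both sides, so this position can move the read-out strongly even when those counts stay untouched. Nothing measured in this set accounts for the size of the step.

As far as these compounds go, what remains open is how bromo, fluoro or an amine on this same ring carbon would fall relative to the iodo and chloro compounds, since a single pair cannot show whether the numbers follow any order among the halogens or whether iodo is the unusual case. From the compounds shown here alone, it is also open whether the same exchange of chloro for iodo would produce a step of similar size on a different sugar substituent pattern or with another group on the neighbouring hydroxy-bearing ring atom.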